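A few compounds are considered here, and "the series" means these few. Any claim that something is new, unique, unknown or untested is made for them only; others in the source may bear on it.

Measured so far in a functional assay on MGC-803 cells (Homo sapiens) for antiproliferative activity, read by MTT assay; on this read-out higher numbers stand for weaker inhibition and lower numbers for stronger inhibition:
- compound 1, `COc1cc2ncnc(NCc3cccc(NC(=O)Nc4ccccc4F)c3)c2cc1OC`, giving 10300 nM
- compound 2, `COc1cc2ncnc(NCc3cccc(NC(=O)Nc4ccc([N+](=O)[O-])cc4)c3)c2cc1OC`, giving 8120 nM

Within the data shown here, compound 2 shows the smaller of the two numbers, but its only neighbour, compound 1, sits within the scatter of it, so the two are not separated on this read-out.

Compound 3, `COc1cc2ncnc(NCc3cccc(NC(=O)Nc4cccc(C(F)(F)F)c4)c3)c2cc1OC`, has not yet been measured in this assay. It differs from compound 2 in one place: 3-(trifluoromethyl)phenyl in place of 4-nitrophenyl on an amide-type nitrogen.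

Among the measured compounds shown here, the single measured step that bears on this change is a 1.3-fold lower number from compound 1 to compound 2 (0.10 log units; within the scatter), which likewise exchanged one aryl group on the same amide-type nitrogen and moved the number by nothing beyond the scatter. For the measured compounds named here, no measured step places a trifluoromethyl-bearing ring at that position, so the only available precedent says an aryl swap there leaves the number roughly where it is.

The expected step is therefore a 1.1-fold higher number from compound 2 to compound 3 (0.04 log units; within the scatter), that is, no change beyond the scatter. Compound 3 is estimated at 9000 nM in this assay, with a range from 3500 nM to 25000 nM.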

Compound 3, half-maximal inhibitory concentration: > 50000 nM
Compound 3 ended at the assay's limit; the forecaster's own chance of this, stated with the estimate: 5%; at least 5.5-fold (0.74 log units) between middle value and limit.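

Among these compounds, the aryl group on the amide-type nitrogen proves not to be a neutral place in this assay: the exchange among the earlier compounds gave only a 1.3-fold lower number from compound 1 to compound 2 (0.10 log units; within the scatter), whereas the new group gives an at least 6.1-fold higher number from compound 2 to compound 3 (0.78 log units; beyond the scatter) and an at least 4.8-fold higher number from compound 1 to compound 3 (0.68 log units; beyond the scatter). Compound 3 gives > 50000 nM, which is a limit of the assay and not a number. Within these three compounds, 2-fluorophenyl and 4-nitrophenyl are not separated on this read-out, while 3-(trifluoromethyl)phenyl stands clearly apart from both.

The full size of both new steps stays open, and the compounds shown do not separate the trifluoromethyl group itself from where it sits on the ring. As far as these compounds go, how an unsubstituted phenyl, or a ring carrying an amine or a carboxylic acid, would read on this nitrogen is also open.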